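One More Halogen Swap: Chloro to Bromo

A few compounds are considered here, and "the series" means these few. Any claim that something is new, unique, unknown or untested is made for them only; others in the source may bear on it.

Measured in a functional assay on FM3A cells (Mus musculus) for antiproliferative activity, with a stated time of 48 h; a higher number here means a weaker inhibitor, a lower number a stronger inhibitor:
- Compound 1 `C=C(Br)C(=O)Nc1ccc(/C=C/C(=O)c2ccc(F)cc2)cc1`: 1200 nM
- Compound 2 `C=C(Br)C(=O)Nc1ccc(/C=C/C(=O)c2ccc(Cl)cc2)cc1`: 1300 nM

Compound 2, at 1300 nM, stands level with compound 1, at 1200 nM. With only these two numbers in hand, there is no meaningful ranking between them.

The next compound, compound 3 `C=C(Br)C(=O)Nc1ccc(/C=C/C(=O)c2ccc(Br)cc2)cc1`, keeps the shared core and alters a single substituent: bromo in place of chloro on an aromatic carbon. In plain terms, this is bromo in place of chloro on an aromatic carbon, para to a large group, so 4-chlorophenyl becomes 4-bromophenyl.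

For the measured compounds named here, one measured step bears on this change, a similar swap of one halogen for another. Putting chloro in place of fluoro on an aromatic carbon gave a 1.1-fold higher number from compound 1 to compound 2 (0.03 log units; within the scatter). That step is very small, and a single step is thin evidence, but it gives no reason to expect a shift beyond the scatter in this assay, in either direction.

The expected step is no change at the digits printed from compound 2 to compound 3 (within the scatter). For compound 3 the estimated value is 1300 nM, with an expected range of 800 nM to 2100 nM.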

Compound 3, half-maximal inhibitory concentration: 1100 nM
Compound 3: middle estimate off by 1.2-fold (0.07 log units), on the high side; low and high end bracket the measured number.
By their numbers in this assay, from the lowest: compounds 3, 1 and 2 (each within the scatter of the next).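

With compound 3, this place on the ring, para to a large group, has now carried fluoro, chloro and bromo. In this assay, bromo in place of chloro gave a 1.2-fold lower number from compound 2 to compound 3 (0.07 log units; within the scatter), and bromo in place of fluoro gave a 1.1-fold lower number from compound 1 to compound 3 (0.04 log units; within the scatter), so the earlier pair's flat result now extends to a third halogen, and all three compounds stand level with one another. Nothing available offers an explanation for this flat result.

The compounds shown carry only halogens at this place, so it remains open whether a methoxy group, an amine or a carboxylic acid there would leave the number level or move it beyond the scatter. Also open is whether a change elsewhere on the shared core would produce a step larger than the scatter, as every step among these three compounds stays within it.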